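This account rests on a few compounds, and the source may have more. Where it says the series, first, only, none or still open, it means among the compounds named here.

Three compounds share one core and differ only in the ring attached to the carbon that carries a double bond to nitrogen. Compound 1 `COc1cc(C(=O)N/N=C/c2ccc(F)c(F)c2)cc(OC)c1OC` gives 43.7% in a functional assay on PC-3 cells (Homo sapiens) for antiproliferative activity, read by MTT assay, tested at 5 uM; a lower number here means a weaker effect, a higher number a stronger effect of the compound at the concentration tested. Compound 2 `COc1cc(C(=O)N/N=C/c2cccc(F)c2)cc(OC)c1OC` gives 64.1% in this assay, and compound 3 `COc1cc(C(=O)N/N=C/c2cccc(C(F)(F)F)c2)cc(OC)c1OC` gives 79.8%. Compound 2 therefore stands second highest of the three: the step of a number 20.4 percentage points higher from compound 1 to compound 2 (beyond the scatter) lies beyond the scatter, and so does the step of a number 15.7 percentage points higher from compound 2 to compound 3 (beyond the scatter). Compound 4 `COc1cc(C(=O)N/N=C/c2c(Cl)cccc2Cl)cc(OC)c1OC` has not been measured; it differs from compound 2 in one place: 2,6-dichlorophenyl in place of 3-fluorophenyl on a carbon with a double bond to nitrogen. Neither measured step tests this exact exchange; both only show that changing the groups on this ring moved the read-out upward by modest amounts, and neither involves chloro. The exchange here is larger than either measured one. A modest shift in either direction is therefore expected rather than none, with no firm lean. The estimate for compound 4 is 62%, with a range from 35% to 88%. This means that a step of a number 2.1 percentage points lower from compound 2 to compound 4 (within the scatter) is expected.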

Compound 4, a percentage reported as inhibition, at one concentration (the size of the read-out at that concentration, not a potency): 52.1%
For compound 4 the middle estimate is 9.9 percentage points above the measured one; measured number inside the range.
By their numbers in this assay, from the lowest: compounds 1 and 4 (each within the scatter of the next); then compound 2; then compound 3.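

In this assay, putting 2,6-dichlorophenyl in place of 3-fluorophenyl on the carbon with a double bond to nitrogen gives a number 12 percentage points lower from compound 2 to compound 4 (beyond the scatter), so changing the ring at this position can lower the read-out as well as raise it, and a ring carrying chloro still gives a measurable effect. Against the 3,4-difluorophenyl ring, the exchange gives a number 8.4 percentage points higher from compound 1 to compound 4 (within the scatter), so compound 4 cannot be told apart from compound 1 although their rings carry different halogens. No measurement is available that explains these differences.

For the compounds shown here, the single exchange from compound 2 to compound 4 changes the halogen, the number of halogens and their places all at once, so the share of each remains unknown. As far as these compounds go, how a ring carrying an amine or a carboxylic acid would behave here also remains open.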